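This account rests on a few compounds, and the source may have more. Where it says the series, first, only, none or still open, it means among the compounds named here.

Measured so far:
compound 1, `O=C1CSC(c2c(Cl)cccc2Cl)N1CCN1CCCCC1`: 100%
compound 2, `O=C1CSC(c2cccc(O)c2)N1CCN1CCCCC1`: 100%

Two analogues of the shared core have been run in an ADME assay on Vero cells (Chlorocebus sabaeus) for cytotoxicity, read by neutral red uptake, tested at 12.3 ug/mL; on this read-out lower numbers stand for a stronger effect and higher numbers for a weaker effect at the one concentration tested. Compound 1 `O=C1CSC(c2c(Cl)cccc2Cl)N1CCN1CCCCC1` gives 100% there. Compound 2 `O=C1CSC(c2cccc(O)c2)N1CCN1CCCCC1` gives 100%. On these numbers compound 2 stands level with compound 1 at the digits reported; the two values lie within the usual scatter of each other, so no order between them can be read and neither shows any effect at the concentration tested.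

Compound 3 `O=C1CSC(c2ccc(F)cc2)N1CCN1CCCCC1` is the next member of the series and has not yet been run in this assay. Its difference from compound 2 is 4-fluorophenyl in place of 3-hydroxyphenyl on a saturated ring carbon. For the measured compounds named here, no step between two measured compounds of this kind is available, so the expectation rests only on the two values at hand, both of which sit at the same level with no effect seen. The expected step is none beyond the scatter, a number 2 percentage points lower from compound 2 to compound 3 (within the scatter). Compound 3 is accordingly estimated at 98% in this assay, with a range from 85% to 105%.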

Compound 3, a percentage reported as activity, at one concentration (the size of the read-out at that concentration, not a potency): 100%
Compound 3: the middle estimate sits 2 percentage points below what was measured, within the range that was stated.
By their numbers in this assay, from the lowest: compounds 1, 2 and 3 (each within the scatter of the next).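

In this assay, replacing 3-hydroxyphenyl with 4-fluorophenyl on a saturated ring carbon gives no change at the digits printed from compound 2 to compound 3 (within the scatter) and extends the level seen so far to a third aryl group at this position. The group that leaves counts 1 hydrogen-bond donor and 1 hydrogen-bond acceptor, and the group that enters counts 0 of each, so across this pair the read-out at the one concentration tested does not follow those counts. Nothing at hand explains the flat result.

This change swaps the hydroxy group for fluorine and alters the substitution number in the same step, so the pair cannot separate the two, and with every value at the same level, the compounds shown do not indicate what would produce an effect in this read-out. From the compounds shown here alone, it remains open whether a carboxylic acid or an aminomethyl group on the aromatic ring, or a longer alkyl chain in place of the aryl group on this carbon, would leave the read-out unchanged.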